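This account rests on a few compounds, and the source may have more. Where it says the series, first, only, none or still open, it means among the compounds named here.

In an assay on membranes from brain for displacement of a labelled ligand from Neuronal acetylcholine receptor; alpha4/beta2 (Rattus norvegicus) (a higher number here means a weaker inhibitor, a lower number a stronger inhibitor), three compounds with a shared core have been measured. Compound 1 `CN1CCC[C@H]1COc1cccnc1[N+](=O)[O-]` gives 9000 nM. Compound 2 `CCN(CC)C(=O)c1ccncc1OC[C@@H]1CCCN1C` gives 2830 nM. Compound 3 `CN1CCC[C@H]1COc1cncc(Cl)c1` gives 0.6 nM, the lowest of the three numbers; compound 2 stands nearest to it with a higher number, and compound 1 furthest, both gaps beyond the scatter, so compound 3 is the strongest inhibitor among the three.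

Compound 4 `COC(=O)c1cncc(OC[C@@H]2CCCN2C)c1` has not yet been measured. It differs from compound 3 in one place: methoxycarbonyl in place of chloro on an aromatic carbon. The chloro of compound 3 is thus replaced by a larger group on the same aromatic carbon of the six-membered aromatic ring with one nitrogen, two atoms from the ring nitrogen.

Going by the values given here, no step between two measured compounds that differ in one place is available, so what the change from chloro to methoxycarbonyl does to the inhibition constant has to be inferred from the three values alone. Compound 3 sits far below compounds 1 and 2, and replacing the small chloro by a four-atom group with two acceptors is expected to weaken inhibition, moving the number upward by a step of a 50-fold higher number from compound 3 to compound 4 (1.70 log units; beyond the scatter), beyond the scatter. For compound 4 an inhibition constant of 30 nM is estimated, within a range from 3 nM to 300 nM.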

Compound 4, inhibition constant: 1.45 nM
The estimate for compound 4 lay 21-fold (1.32 log units) above the measured number; the whole stated range lies above it.
By their numbers in this assay, from the lowest: compound 3; then compound 4; then compound 2; then compound 1.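

Going by these compounds alone, measured in this assay, the replacement of chloro by methoxycarbonyl gives a 2.4-fold higher number from compound 3 to compound 4 (0.38 log units; beyond the scatter) and is a modest change, the first step that can be read at this aromatic carbon, two atoms from the ring nitrogen. The position therefore accepts a group of 4 heavy atoms with 2 hydrogen-bond acceptors in place of a single chlorine, and compound 4 with 1.45 nM stays in the low nanomolar range of compound 3 with 0.6 nM in this assay. No measurement at hand explains why so large a replacement shifts the number so little.

On these data alone, with only chloro and methoxycarbonyl seen at this carbon, it remains open whether the same holds for a carboxylic acid, an amine or a primary amide, or for a longer ester chain such as ethoxycarbonyl. This single step also cannot separate the part played by the carbonyl from that of the methoxy end, which a comparison with an acetyl group or a methoxymethyl group could address.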